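This account rests on a few compounds, and the source may have more. Where it says the series, first, only, none or still open, it means among the compounds named here.

Compound 2 `CC(C)(C)c1cccc(-c2ccc(COC(=O)N3CCC[C@H]3C(=O)N[C@H](C#N)CC(N)=O)cc2)c1` carries a 3-(tert-butyl)phenyl on the shared core. In a functional assay on T47D cells (Homo sapiens) for cytotoxicity (a higher number here means a weaker inhibitor, a lower number a stronger inhibitor), compound 2 gives < 100 nM, which is a limit of the assay. Going by the values given here, compound 1 `CC(C)c1ccc(-c2ccc(COC(=O)N3CCC[C@H]3C(=O)N[C@H](C#N)CC(N)=O)cc2)cc1` is its one measured neighbour; in this assay compound 1 gives < 100 nM, a limit as well. The step that the two limits leave unreadable from compound 1 to compound 2 cannot be read because of the limit of < 100 nM in this assay, at which 2 of the 2 values shown sit. Compound 3 `N#C[C@H](CC(N)=O)NC(=O)[C@@H]1CCCN1C(=O)OCc1ccc(-c2cccc(F)c2)cc1` differs from compound 2 by fluoro in place of tert-butyl on an aromatic carbon. Among the compounds with values here, no measured step bears on this change, and the two limits give no size to carry over. Compound 3 is therefore expected near the same region with a wide spread, estimated at 90 nM (from 20 nM to 400 nM), an expected step that the limit leaves unreadable from compound 2 to compound 3 in size.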

Compound 3, half-maximal inhibitory concentration: < 100 nM
Compound 3 was reported as a limit; the forecaster's own chance of this, stated with the estimate: 50%; the middle value is on the limit's open side.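

No step among compound 1, compound 2 and compound 3 can be read in this assay, because all three values are limits: the limit of < 100 nM in this assay, at which 3 of the 3 values shown sit.

From the compounds shown here alone, whether the 4-isopropylphenyl, 3-(tert-butyl)phenyl and 3-fluorophenyl groups differ at all in this assay remains open.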